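The source may report more compounds than this note shows. Statements on the series, on what has been measured and on what is new or still open speak of the compounds shown alone.

Working notes on the series. Compound 1, `Clc1ccc(Nc2nc3ccc(N4CCCC4)cc3nc2Nc2ccc(Cl)c(Cl)c2)cc1Cl`, stands at "nd" (no result reported) in a toxicity assay on HepG2 cells (Homo sapiens) for cytotoxicity, read by MTT assay, with a stated time of 24 h (on this read-out lower numbers stand for higher toxicity in this test and higher numbers for lower toxicity in this test), that is, with no result reported. Compound 2, `O=[N+]([O-])c1ccc2nc(Nc3ccc(Br)cc3)c(Nc3ccc(Br)cc3)nc2c1`, gives 8720 nM there, and compound 3, `O=[N+]([O-])c1ccc2nc(Nc3ccc(F)cc3)c(Nc3ccc(F)cc3)nc2c1`, gives 10200 nM; the two numbers lie within the scatter of each other, so compound 2 stands level with compound 3 on the numbers shown, with nothing to separate them. The step from compound 2 to the unmeasured compound 4, `Brc1ccc(Nc2nc3ccccc3nc2Nc2ccc(Br)cc2)cc1`, is hydrogen in place of nitro on an aromatic carbon. Among the measured compounds shown here, no pair of measured compounds that differ in one place is available, so the size of this step is not backed by any measured step; the expectation is a change within the scatter in this assay, with no clear direction, giving an estimated step of a 1.1-fold higher number from compound 2 to compound 4 (0.06 log units; within the scatter). Compound 4 is therefore expected to give about 10000 nM, in a range of 4000 nM to 25000 nM.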

Compound 4, half-maximal cytotoxic concentration: 7120 nM
The estimate for compound 4 lay 1.4-fold (0.15 log units) above the measured number; the measured number falls inside the stated range.
By their numbers in this assay, from the lowest: compounds 4, 2 and 3 (each within the scatter of the next).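

In this assay, hydrogen in place of nitro on this aromatic carbon, meta to a fused ring and para to a fused ring, gives a 1.2-fold lower number from compound 2 to compound 4 (0.09 log units; within the scatter). Among the compounds shown here, this is the first measured step at this position, and it shows that removing nitro from compound 2 leaves the number within the scatter. No measured information on these compounds offers an explanation for this result. From the compounds shown here alone, whether an amine or a carboxylic acid at this position would also stay within the scatter remains open, as does whether the same change on compound 3 would behave alike.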